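Acetoxymethyl in Place of Furan-2-yl on the Hydroxamate

A few compounds are considered here, and "the series" means these few. Any claim that something is new, unique, unknown or untested is made for them only; others in the source may bear on it.

Compound 3 `CC(c1ccc2oc(-c3ccccc3)cc2c1)N(O)C(=O)c1ccco1` stands lowest of the three numbers in an assay on RBL cells for inhibition of Polyunsaturated fatty acid 5-lipoxygenase (Rattus norvegicus) (a lower number here means a stronger inhibitor, a higher number a weaker inhibitor), where compound 3 gives 40 nM. Compound 2 `COc1ccc(C(=O)N(O)C(C)c2ccc3oc(-c4ccccc4)cc3c2)cc1OC` gives 200 nM and compound 1 `CC(c1ccc2oc(-c3ccccc3)cc2c1)N(O)C(=O)c1ccccc1` gives 4830 nM. The measured steps are a 24-fold lower number from compound 1 to compound 2 (1.38 log units; beyond the scatter), a 120-fold lower number from compound 1 to compound 3 (2.08 log units; beyond the scatter) and a 5.0-fold lower number from compound 2 to compound 3 (0.70 log units; beyond the scatter); each swaps the group on the carbonyl carbon. Compound 4 `CC(=O)OCC(=O)N(O)C(C)c1ccc2oc(-c3ccccc3)cc2c1` alters the same place: acetoxymethyl in place of furan-2-yl on a carbonyl carbon. Among the compounds with values here, no measured step involves acetoxymethyl, so the three steps bear on it only by showing that this position shifts the number strongly, with furan-2-yl giving the lowest value seen. A higher number is therefore expected, most likely a modest to large step. The expected step is a 7.5-fold higher number from compound 3 to compound 4 (0.88 log units; beyond the scatter). For compound 4 the estimate is 300 nM, with a range from 60 nM to 1500 nM.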

Compound 4, half-maximal inhibitory concentration: 160 nM
Compound 4: middle estimate off by 1.9-fold (0.27 log units), on the high side; low and high end bracket the measured number.
By their numbers in this assay, from the lowest: compound 3; then compounds 4 and 2 (each within the scatter of the next); then compound 1.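

A group with no ring can still give a low number on this carbonyl carbon: acetoxymethyl brings a 30-fold lower number from compound 1 to compound 4 (1.48 log units; beyond the scatter) and cannot be told apart from 3,4-dimethoxyphenyl, with a 1.3-fold lower number from compound 2 to compound 4 (0.10 log units; within the scatter). Furan-2-yl nonetheless keeps its lead over this open-chain group, with a 4.0-fold higher number from compound 3 to compound 4 (0.60 log units; beyond the scatter). Nothing available explains why these groups differ.

From the compounds shown here alone, whether a plain methyl, a hydroxymethyl or an aminomethyl group on the carbonyl carbon would keep the number this low stays open. So does whether a thiophene ring would match furan-2-yl.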